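Swapping the Urea Aryl Group on a Compound with a Low Number

The compounds below may be only part of what the source reports. "The series", "measured", "known", "first", "only" and "open" are said of these compounds alone.

Compound 1 `COc1cc(NC(=O)Nc2cc(Nc3cccc(C(C)(C)C)c3)ncn2)cc(OC)c1` carries a 3,5-dimethoxyphenyl on an amide-type nitrogen whose other neighbour is a carbonyl carbon. In a functional assay on NCI-H520 cells (Homo sapiens) for inhibition, read by MTT assay, with a stated time of 48 h, tested at 10 uM (a higher number here means more inhibition at the concentration tested (going by the name of the read-out), a lower number less inhibition), compound 1 gives 13.1%. Compound 2 `COc1cc(NC(=O)Nc2cc(Nc3cc(C(F)(F)F)ccc3OC)ncn2)cc(OC)c1` gives 63% in this assay, and compound 3 `COc1ccc(C(F)(F)F)cc1Nc1cc(NC(=O)Nc2c(Cl)cccc2Cl)ncn1` gives 33%; the difference between the cores of compound 1 and compound 2 is not broken down here. The change 2,6-dichlorophenyl in place of 3,5-dimethoxyphenyl on an amide-type nitrogen produced a number 30 percentage points lower from compound 2 to compound 3 (beyond the scatter). Compound 4 `CC(C)(C)c1cccc(Nc2cc(NC(=O)Nc3c(Cl)cccc3Cl)ncn2)c1` has not yet been measured; it arises from compound 1 by the same change, (2,6-dichlorophenyl in place of 3,5-dimethoxyphenyl on an amide-type nitrogen). Compound 1 already gives only 13.1%, leaving little room for a fall as large as a number 30 percentage points lower from compound 2 to compound 3 (beyond the scatter). Compound 4 is therefore expected to give 8%, between 0% and 22%. The step this estimate implies, resting on the direction of a number 30 percentage points lower from compound 2 to compound 3 (beyond the scatter), is expected to be a number 5.1 percentage points lower from compound 1 to compound 4 (within the scatter).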

Compound 4, a percentage reported as inhibition, at one concentration (the size of the read-out at that concentration, not a potency): 29.6%
Compound 4: middle estimate off by 21.6 percentage points, on the low side; measured number above the stated range.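

Replacing 3,5-dimethoxyphenyl with 2,6-dichlorophenyl on the amide-type nitrogen produced a number 16.5 percentage points higher from compound 1 to compound 4 (beyond the scatter) in this assay. The change therefore does not carry a fixed effect from one core to the other in this series, and even its direction differs between the two cores: the same change on two cores in this assay, a number 30 percentage points lower (beyond the scatter) from compound 2 to compound 3 and a number 16.5 percentage points higher (beyond the scatter) from compound 1 to compound 4, 46.5 percentage points apart, beyond the scatter of two such steps. For the compounds shown here, this rests on only two pairs of compounds, and it does not show why the direction differs or how the change would behave on any further core.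

The compounds shown leave open how a plain phenyl or a pyridine ring would behave on this amide-type nitrogen on either core. They also leave open how the two groups compare on a core bearing a carboxylic acid or an amine.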